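Replacing a Basic Ring with Imidazole on a Quinoline Sulfonamide

A few compounds are considered here, and "the series" means these few. Any claim that something is new, unique, unknown or untested is made for them only; others in the source may bear on it.

Going by the values given here, compound 2 `COc1ncc(-c2ccc3nccc(-c4ccc(CN5CCN(C(C)C)CC5)cc4)c3c2)cc1NS(=O)(=O)c1ccc(F)cc1F` has the lowest of the two numbers so far: in a functional assay on A549 cells (Homo sapiens) for cytotoxicity, read by MTT assay, with a stated time of 72 h (a lower number here means a stronger inhibitor, a higher number a weaker inhibitor), compound 2 gives 1.9 nM, while compound 1 `COc1ncc(-c2ccc3nccc(N4CCCC4)c3c2)cc1NS(=O)(=O)c1ccc(F)cc1F` gives 3410 nM, a gap well beyond the scatter. Compound 3 `COc1ncc(-c2ccc3nccc(-c4ccc(Cn5ccnc5)cc4)c3c2)cc1NS(=O)(=O)c1ccc(F)cc1F` keeps everything else and changes one group: 1H-imidazol-1-yl in place of 4-isopropylpiperazin-1-yl on a saturated chain carbon bound to an aromatic carbon. Among the compounds with values here, with no measured pair of this kind to lean on, the step is estimated to raise the number moderately, giving weaker inhibition, as an 11-fold higher number from compound 2 to compound 3 (1.02 log units; beyond the scatter). Compound 3 is therefore expected to show about 20 nM in this assay, within a range from 4 nM to 150 nM.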

Compound 3, half-maximal inhibitory concentration: 30.8 nM
Beside the measured number, compound 3's estimate is 1.5-fold (0.19 log units) below it; measured number inside the range.
By their numbers in this assay, from the lowest: compound 2; then compound 3; then compound 1.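

In this assay, the place on a saturated chain carbon bound to an aromatic carbon proves sensitive to the group it carries: 1H-imidazol-1-yl in place of 4-isopropylpiperazin-1-yl gives a 16-fold higher number from compound 2 to compound 3 (1.21 log units; beyond the scatter). Even so, compound 3 keeps most of the lead over the pyrrolidin-1-yl compound, with a 110-fold lower number from compound 1 to compound 3 (2.04 log units; beyond the scatter). Nothing measured here gives a reason for either step.

This single swap changes ring size and aromatic character together, so the two cannot be separated. Going by these compounds, whether a morpholine ring or a dimethylamino group at the same place would land nearer compound 2 or compound 3 remains open.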